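The compounds below may be only part of what the source reports. "The series", "measured", "known", "first", "only" and "open" are said of these compounds alone.

In an ADME assay on HOS cells (Homo sapiens) for cytotoxicity (on this read-out lower numbers stand for higher toxicity in this test and higher numbers for lower toxicity in this test), compound 1 (`CN(Cc1nc2ccccc2n1CCN)C1CCCc2cccnc21`) gives > 20000 nM as a limit and not a number. Compound 2 (`CN(Cc1nc2cccc(C(=O)NCCCN)c2[nH]1)C1CCCc2cccnc21`) likewise gives > 20000 nM as a limit. That is all the data show so far (the limit of > 20000 nM in this assay, at which 2 of the 2 values shown sit). Compound 3 (`CN(Cc1nc2cccc(CCCN3CCCCC3)c2[nH]1)C1CCCc2cccnc21`) carries 3-(piperidin-1-yl)propyl in place of (3-aminopropyl)carbamoyl on an aromatic carbon. Going by the values given here, no measured step guides this change, so only a small move toward lower numbers in this assay is expected (an at least 1.3-fold lower number from compound 2 to compound 3 (0.12 log units; that floor lies within the scatter)). Compound 3 is estimated at 15000 nM with a range from 5000 nM to 40000 nM and may also turn out as a limit.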

Compound 3, half-maximal cytotoxic concentration: 8700 nM
Compound 3: middle estimate off by 1.7-fold (0.24 log units), on the high side, and the stated range covers the measured number.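

Going by these compounds alone, compound 3 is the first compound here to give a number rather than a limit in this assay, so a change on this aromatic carbon can bring the read-out within the measured range. Putting 3-(piperidin-1-yl)propyl in place of (3-aminopropyl)carbamoyl gives an at least 2.2-fold lower number from compound 2 to compound 3 (0.36 log units; beyond the scatter). The full size of this step cannot be read because compound 2 stands at a limit: the limit of > 20000 nM in this assay, at which 2 of the 3 values shown sit.

Still open, going by these compounds, is whether the loss of the amide or the arrival of the piperidine ring drives the step. A plain 3-aminopropyl chain or a morpholine ring at the chain end would help separate the two.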